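Lengthening the Chain from Compound 3 to Compound 4

The source may hold more compounds than are shown below. What is called first, only, known or untested is meant among the compounds shown, and "the series" means these compounds.

In a functional assay (Nicotiana tabacum) (a higher number here means a weaker inhibitor, a lower number a stronger inhibitor), compound 1 (`CNc1nc(SC)nc2ncccc12`) reads 2920 nM and compound 2 (`CCCNc1nc(SC)nc2ncccc12`) reads 270 nM while compound 3 (`CCCCCNc1nc(SC)nc2ncccc12`) stands between them at 650 nM as the middle of the three numbers. The change to compound 4 (`CCCCCCCNc1nc(SC)nc2ncccc12`) is ethyl in place of hydrogen on a saturated chain carbon, five bonds along the chain from a nitrogen on an aromatic ring and it falls on a saturated chain carbon, five bonds along the chain from a nitrogen on an aromatic ring. The closest measured step, with ethyl entering three bonds along the chain, is a 2.4-fold higher number from compound 2 to compound 3 (0.38 log units; beyond the scatter) and it was modest. Ethyl on a saturated chain carbon bound to a nitrogen on an aromatic ring gave an 11-fold lower number from compound 1 to compound 2 (1.03 log units; beyond the scatter) which was large and ran the opposite way. A further modest rise is therefore expected, and the estimate is a 2.2-fold higher number from compound 3 to compound 4 (0.33 log units; beyond the scatter) in this direction. For compound 4 the estimated value is 1400 nM (range 600 nM to 3500 nM).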

Compound 4, half-maximal inhibitory concentration: 4070 nM
The estimate for compound 4 lay 2.9-fold (0.46 log units) below the measured number, outside the stated range (above it).
By their numbers in this assay, from the lowest: compound 2; then compound 3; then compounds 1 and 4 (each within the scatter of the next).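

In this assay, ethyl in place of hydrogen five bonds along the chain gave a 6.3-fold higher number from compound 3 to compound 4 (0.80 log units; beyond the scatter), so lengthening continues to cost activity at this far end of the chain. Taken from the propyl chain of compound 2, the same extension amounts to a 15-fold higher number from compound 2 to compound 4 (1.18 log units; beyond the scatter), while the comparison with the short chain gives a 1.4-fold higher number from compound 1 to compound 4 (0.14 log units; within the scatter), so the gain seen with propyl is gone. The added ethyl therefore pushes the number in opposite directions at different places on the chain: the same change on two cores in this assay, an 11-fold lower number (1.03 log units; beyond the scatter) from compound 1 to compound 2 and a 6.3-fold higher number (0.80 log units; beyond the scatter) from compound 3 to compound 4, 68-fold (1.83 log units) apart, beyond the scatter of two such steps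

Going by these compounds, whether a butyl chain in place of the propyl chain of compound 2 would lower the number further remains open. So does whether a pentyl chain ending in an amine or a carboxylic acid would read differently from compound 3.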